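This account rests on a few compounds, and the source may have more. Where it says the series, first, only, none or still open, it means among the compounds named here.

The study compares three compounds built on a shared core. Compound 1 `O=C(O)COc1ccc(Cl)cc1C#Cc1ccncc1` is the simplest of them and, in an assay on CHO cells for displacement of a labelled ligand from prostaglandin D2 receptor 2 (Homo sapiens), read by scintillation counting (on this read-out higher numbers stand for weaker inhibition and lower numbers for stronger inhibition), compound 1 gives 601 nM. Compound 2 `Cc1ccc(S(=O)(=O)N2CCN(C)CC2)cc1C#Cc1cc(Cl)ccc1OCC(=O)O` carries a (4-methylpiperazin-1-yl)sulfonyl group on its core, and in this assay compound 2 gives 21 nM. Of the two numbers measured, compound 2 has the lower one, and its distance from compound 1 lies well beyond the usual scatter of this assay. Compound 3 `Cc1ccc(S(=O)(=O)NC(C)(C)C)cc1C#Cc1cc(Cl)ccc1OCC(=O)O` has not yet been measured. It differs from compound 2 in one place: (tert-butyl)amino in place of 4-methylpiperazin-1-yl on a sulfonyl sulfur. Among the compounds with values here, no measured pair in the study shows what this kind of change does, so the direction of the step is uncertain. The account expects the step from compound 2 to compound 3 in this assay to be small, a 1.4-fold higher number from compound 2 to compound 3 (0.15 log units; within the scatter), not far beyond the scatter. On that basis compound 3 is estimated at 30 nM, with an expected range from 8 nM to 120 nM.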

Compound 3, inhibition constant: 5 nM
For compound 3 the middle estimate is 6.0-fold (0.78 log units) above the measured one; the whole stated range lies above it.
By their numbers in this assay, from the lowest: compound 3; then compound 2; then compound 1.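

In this assay, (tert-butyl)amino in place of 4-methylpiperazin-1-yl on the sulfonyl sulfur gives a 4.2-fold lower number from compound 2 to compound 3 (0.62 log units; beyond the scatter), so what sits on this sulfur does affect the read-out. Within the data shown here, this is the only measured change at this place, and it shows that the six-membered non-aromatic ring can give way to an open group with fewer heavy atoms and one hydrogen-bond donor without any loss on this read-out. Nothing at hand bears on why the number falls.

The compounds shown do not separate the loss of the ring from the gain of the hydrogen-bond donor, since both come with the same step. Groups such as methylamino, dimethylamino or piperidin-1-yl on the same sulfur would tell these apart, and how they compare with (tert-butyl)amino remains open.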